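Working notes on the benzyl ether substituent

A few compounds are considered here, and "the series" means these few. Any claim that something is new, unique, unknown or untested is made for them only; others in the source may bear on it.

Measured so far in a functional assay on MGC-803 cells (Homo sapiens) for inhibition, read by MTT assay, with a stated time of 48 h; a lower number here means a stronger inhibitor, a higher number a weaker inhibitor: compound 1 `Cc1ccc(NC(=S)NC(=O)c2ccc(OCc3ccccc3)cc2)cc1-c1nc2ccccc2[nH]1` gives 60700 nM. Compound 2 `Cc1ccc(COc2ccc(C(=O)NC(=S)Nc3ccc(C)c(-c4nc5ccccc5[nH]4)c3)cc2)cc1` gives 4980 nM. Compound 3 `Cc1ccc(NC(=S)NC(=O)c2ccc(OCc3cccc(F)c3)cc2)cc1-c1nc2ccccc2[nH]1` is reported only as a limit of the assay, > 100000 nM.

Compound 3 therefore stands at the top of the numbers shown; it sits at the limit of > 100000 nM in this assay, at which 1 of the 3 values shown sits, and no number is known for it, only that floor. Its relation to the others is given by an at least 1.6-fold higher number from compound 1 to compound 3 (0.21 log units; that floor lies within the scatter) and by an at least 20-fold higher number from compound 2 to compound 3 (1.30 log units; beyond the scatter).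

The next compound, compound 4 `Cc1ccc(NC(=S)NC(=O)c2ccc(OCc3ccccc3Cl)cc2)cc1-c1nc2ccccc2[nH]1`, differs from compound 3 in one place: 2-chlorophenyl in place of 3-fluorophenyl on a saturated chain carbon bound to an oxygen on an aromatic ring.

Bearing on this step are an at least 1.6-fold higher number from compound 1 to compound 3 (0.21 log units; that floor lies within the scatter), which shows that adding the fluorine to the benzyl ring of compound 1 did not move the number beyond the scatter as far as the limit allows one to tell, and a 12-fold lower number from compound 1 to compound 2 (1.09 log units; beyond the scatter), which shows that a methyl on that ring can shift the number a great deal. Among the compounds with values here, no measured compound carries a chlorine, and none carries a substituent at the place where the chlorine of compound 4 sits, so the direction of the step is open. Taking compound 1 as the nearest anchor and allowing for the fact that compound 3 is only a limit, the step of an at least 2.0-fold lower number from compound 3 to compound 4 (0.30 log units; that floor lies within the scatter) is expected to bring the number back down toward compound 1, but with wide uncertainty. Compound 4 is estimated at 50000 nM, in the range 12000 nM to 200000 nM.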

Compound 4, half-maximal inhibitory concentration: 45000 nM
Beside the measured number, compound 4's estimate is 1.1-fold (0.05 log units) above it; low and high end bracket the measured number.
By their numbers in this assay, from the lowest: compound 2; then compounds 4 and 1 (each within the scatter of the next). At a limit, above all of these: compound 3.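

In this assay, the 2-chlorophenyl group of compound 4 reads like the unsubstituted phenyl group on the saturated chain carbon: a 1.3-fold lower number from compound 1 to compound 4 (0.13 log units; within the scatter), so chloro in place of hydrogen on this ring gives no shift that can be read. Of the substituted rings with a readable number, the 4-methylphenyl group of compound 2 therefore stands alone, and the 2-chlorophenyl group differs from it by a 9.0-fold higher number from compound 2 to compound 4 (0.96 log units; beyond the scatter), which makes the low number of compound 2 look tied to that group and not to any substituent on the ring. Compound 3 remains a limit of the assay and not a number, and the step out of it, an at least 2.2-fold lower number from compound 3 to compound 4 (0.34 log units; beyond the scatter), is a floor only: the limit of > 100000 nM in this assay, at which 1 of the 4 values shown sits.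

Open, from the compounds shown here alone, is whether the low number of compound 2 belongs to the methyl itself or to its place on the ring, a question that a 2-methylphenyl group on the same chain carbon would address. Also open, going by these compounds, is how a 4-methoxyphenyl, a 4-aminophenyl or a 4-carboxyphenyl group would read there.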